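Aryl sulfone amides as K-ATP channel inhibitors: compound 4

A few compounds are considered here, and "the series" means these few. Any claim that something is new, unique, unknown or untested is made for them only; others in the source may bear on it.

Measured compounds:
Compound 1 `CC(O)(C(=O)Nc1ccc(S(=O)(=O)c2ccc(F)cc2)cc1)C(F)(F)F` — 8600 nM
Compound 2 `CC(O)(C(=O)Nc1ccc(S(=O)(=O)c2cccc(O)c2)cc1)C(F)(F)F` — 18000 nM
Compound 3 `Cc1ccc(S(=O)(=O)c2ccc(NC(=O)C(C)(O)C(F)(F)F)cc2)cc1` — > 30000 nM

In a functional assay (Cavia porcellus) with sulfonylurea receptors; K-ATP channels (Homo sapiens) as the target (a higher number here means a weaker inhibitor, a lower number a stronger inhibitor), compound 1 gives 8600 nM and compound 2 gives 18000 nM. For compound 3 this assay gives only a limit, > 30000 nM, so its position among the measured compounds is known only as weaker than both others and not as a number (the limit of > 30000 nM in this assay, at which 1 of the 3 values shown sits). The steps into compound 3 are an at least 3.4-fold higher number from compound 1 to compound 3 (0.54 log units; beyond the scatter) and an at least 1.6-fold higher number from compound 2 to compound 3 (0.22 log units; that floor lies within the scatter); the step of a 2.1-fold higher number from compound 1 to compound 2 (0.32 log units; beyond the scatter) shows how much the group on the sulfonyl sulfur moves the read-out.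

Compound 4 `CC(O)(C(=O)Nc1ccc(S(=O)(=O)c2ccccn2)cc1)C(F)(F)F` differs from compound 3 as follows: pyridin-2-yl in place of 4-methylphenyl on a sulfonyl sulfur. For the measured compounds named here, no measured step replaces an aryl on the sulfonyl sulfur with a heteroaryl, so the expectation rests on the spread of the three measured compounds. Since compound 3 sits at a limit, compound 4 is expected near the values of compound 1 and compound 2, a step of an at least 2.0-fold lower number from compound 3 to compound 4 (0.30 log units; that floor lies within the scatter) back into that range. Compound 4 is therefore estimated at 15000 nM, within 5000 nM to 40000 nM in this assay.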

Compound 4, half-maximal inhibitory concentration: 600 nM
Beside the measured number, compound 4's estimate is 25-fold (1.40 log units) above it, and the stated range ends above it.
By their numbers in this assay, from the lowest: compound 4; then compound 1; then compound 2. At a limit, above all of these: compound 3.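

For the compounds shown here, on the sulfonyl sulfur, the group can move this assay much further than the earlier carbon-only aryl groups showed: pyridin-2-yl, the only group here with a ring nitrogen, gives a 14-fold lower number from compound 1 to compound 4 (1.16 log units; beyond the scatter) and a 30-fold lower number from compound 2 to compound 4 (1.48 log units; beyond the scatter), against a 2.1-fold higher number from compound 1 to compound 2 (0.32 log units; beyond the scatter) among the earlier groups. Against 4-methylphenyl, the change gives an at least 50-fold lower number from compound 3 to compound 4 (1.69 log units; beyond the scatter), which places compound 4 as the strongest inhibitor of the four. The figure for compound 3 is a limit, so that step is only a floor: the limit of > 30000 nM in this assay, at which 1 of the 4 values shown sits.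

On these data alone, whether pyridin-3-yl, pyridin-4-yl or pyrimidin-2-yl on the sulfonyl sulfur would give a similar number stays open, so the part played by the ring nitrogen and its place in the ring cannot be told from these compounds. Also open, as far as these compounds go, is whether the gain holds with an amine in place of the hydroxyl on the shared core.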